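The compounds below may be only part of what the source reports. "The series", "measured", "known", "first", "only" and "open" are said of these compounds alone.

Three ureas built on one shared core have been tested in a functional assay on T-24 cells (Homo sapiens) for antiproliferative activity, read by MTT assay, with a stated time of 48 h; a higher number here means a weaker inhibitor, a lower number a stronger inhibitor. Compound 1 `O=C(Nc1cccc(CNc2nccnc2Cl)c1)Nc1cccc2ccccc12` reaches only the limit of the assay, > 40000 nM, the point at which one of the three values sits (the limit of > 40000 nM in this assay, at which 1 of the 3 values shown sits). Compound 2 `CCOc1ccc(NC(=O)Nc2cccc(CNc3nccnc3Cl)c2)cc1` gives 9080 nM, the higher of the two numbers actually reached. Compound 3 `CCc1ccc(NC(=O)Nc2cccc(CNc3nccnc3Cl)c2)c(CC)c1` gives 6390 nM, and the gap between compound 2 and compound 3 lies within the usual scatter, so the two cannot be told apart. Compound 4 `O=C(Nc1cccc(CNc2nccnc2Cl)c1)Nc1ccc(Cl)c(Cl)c1` has not yet been measured. Among the measured compounds shown here, its single change from compound 2 is 3,4-dichlorophenyl in place of 4-ethoxyphenyl on an amide-type nitrogen. For the measured compounds named here, no measured pair shows this kind of exchange, so no step is available to lean on; the 3,4-dichlorophenyl brings no hydrogen-bond acceptor where the 4-ethoxyphenyl had one, and the measured compounds say nothing about what that does here. The step expected is a 1.7-fold lower number from compound 2 to compound 4 (0.22 log units; within the scatter), a slight lowering of the number that may not clear the scatter. For compound 4 in this assay the estimate is 5500 nM, with a range from 1500 nM to 20000 nM.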

Compound 4, half-maximal inhibitory concentration: 5210 nM
The estimate for compound 4 lay 1.1-fold (0.02 log units) above the measured number; the range from low to high includes it.
By their numbers in this assay, from the lowest: compounds 4, 3 and 2 (each within the scatter of the next). At a limit, above all of these: compound 1.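

In this assay, among the compounds shown here, the exchange of 4-ethoxyphenyl for 3,4-dichlorophenyl on an amide-type nitrogen gives the first direct step at this position, a 1.7-fold lower number from compound 2 to compound 4 (0.24 log units; within the scatter), so compound 2 and compound 4 cannot be told apart. The 4-ethoxyphenyl counts a hydrogen-bond acceptor and the 3,4-dichlorophenyl counts none, so that acceptor is not needed to keep activity at this level in this pair. Nothing measured here speaks to why the two groups perform alike.

As far as these compounds go, it remains open whether a phenyl ring carrying an amine or a carboxylic acid on this nitrogen would give a step beyond the scatter. Nor can the compounds shown tell what each chlorine contributes, which a phenyl ring with a single chlorine would address.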